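The source may hold more compounds than are shown below. What is called first, only, known or untested is meant among the compounds shown, and "the series" means these compounds.

Compounds measured in an assay on COS7 cells for inhibition of Ectonucleotide pyrophosphatase/phosphodiesterase family member 1 (Homo sapiens), with a stated time of 35 min; on this read-out lower numbers stand for stronger inhibition and higher numbers for weaker inhibition:
- compound 1 `O=C(NS(=O)(=O)c1ccccc1)n1ccc2cccnc21`: 4500 nM
- compound 2 `O=C(NS(=O)(=O)c1ccccc1)n1ccc2c(Cl)ccnc21`: 1080 nM
- compound 3 `O=C(NS(=O)(=O)c1ccc2ccccc2c1)n1ccc2c(Cl)ccnc21`: 3290 nM

In this assay compound 2 gives the lowest number of the three. Going by the values given here, compound 3 sits nearest, and its value and that of compound 2 lie beyond the scatter of one another; compound 1 sits furthest, and the one single-point step among the measured compounds is a 4.2-fold lower number from compound 1 to compound 2 (0.62 log units; beyond the scatter), a modest step.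

Compound 4 `CN(C)c1ccnc2c1ccn2C(=O)NS(=O)(=O)c1ccccc1` follows from compound 2 by dimethylamino in place of chloro on an aromatic carbon, so the change is dimethylamino in place of chloro on an aromatic carbon. Among the compounds with values here, only the step from compound 1 to compound 2 bears on this position, and it shows that introducing chloro there lowers the number; no measured pair tells what a group other than chloro does at the same place. The expectation is therefore a change in the number within the range of what has been seen so far, with the direction left open, though a somewhat higher number than compound 2 is estimated, since the measured gain at this position rests on chloro alone. For compound 4 the estimated value in this assay is 2500 nM, with a range from 800 nM to 8000 nM, which corresponds to an expected step of a 2.3-fold higher number from compound 2 to compound 4 (0.36 log units; beyond the scatter).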

Compound 4, half-maximal inhibitory concentration: 2770 nM
Compound 4: the middle estimate sits 1.1-fold (0.04 log units) below what was measured; the range from low to high includes it.
By their numbers in this assay, from the lowest: compound 2; then compounds 4, 3 and 1 (each within the scatter of the next).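

In this assay, the position opposite the ring nitrogen now carries a second group, and the gain seen with chloro does not carry over to dimethylamino: the swap gives a 2.6-fold higher number from compound 2 to compound 4 (0.41 log units; beyond the scatter), a step beyond the scatter. Measured against the unsubstituted parent, dimethylamino gives a 1.6-fold lower number from compound 1 to compound 4 (0.21 log units; within the scatter), which lies within the scatter, so at this place it cannot be told apart from hydrogen, and of the two groups shown only chloro separates from hydrogen. No measurement on hand accounts for the difference between chloro and dimethylamino.

Going by these compounds, whether the gain is special to chloro stays open, and fluoro, bromo or methoxy at the same place would bear on that. On these data alone, whether a primary amine or morpholine would match dimethylamino also remains open.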